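Triazolylmethyl in place of a tertiary alcohol on the chain

The source may report more compounds than this note shows. Statements on the series, on what has been measured and on what is new or still open speak of the compounds shown alone.

The shared core of compound 1 `CCCCNc1nc(N)nc(C)c1CCCCc1ccccc1`, compound 2 `CCCCNc1nc(N)nc(C)c1CCCCO` and compound 3 `CCCCNc1nc(N)nc(C)c1CCC(C)(C)O` carries a saturated chain whose end varies. In an assay on HEK293 cells for agonist activity at Toll-like receptor 8 (Homo sapiens), read by spectrophotometry (a higher number here means that more compound is needed for the effect, a lower number that less compound is needed), compound 1 gives 857 nM, compound 2 gives 1310 nM and compound 3 gives 3140 nM. Compound 3 therefore stands highest of the three numbers. The step of a 1.5-fold higher number from compound 1 to compound 2 (0.18 log units; within the scatter) is within the scatter, whereas the step of a 2.4-fold higher number from compound 2 to compound 3 (0.38 log units; beyond the scatter) is beyond it.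

Compound 4 `CCCCNc1nc(N)nc(C)c1CCCn1cncn1` differs from compound 3 by (1H-1,2,4-triazol-1-yl)methyl in place of 1-hydroxy-1-methylethyl on a saturated chain carbon, two bonds along the chain from an aromatic carbon. For the measured compounds named here, two measured steps bear on this change. The step of a 2.4-fold higher number from compound 2 to compound 3 (0.38 log units; beyond the scatter) shows that the branched hydroxy end gave the higher number, so removing it in compound 4 may undo part of that rise. The step of a 1.5-fold higher number from compound 1 to compound 2 (0.18 log units; within the scatter) shows that an aromatic ring at the chain end, as in compound 1, and a hydroxy end sit within the scatter of each other, so an aromatic ring at the end of the chain of compound 4 need not raise the number. The step of a 2.6-fold lower number from compound 3 to compound 4 (0.42 log units; beyond the scatter) is therefore expected, a modest fall toward the level of compound 2. The estimate for compound 4 in this assay is 1200 nM, with a range from 400 nM to 3500 nM.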

Compound 4, half-maximal effective concentration: 1050 nM
For compound 4 the middle estimate is 1.1-fold (0.06 log units) above the measured one; the range from low to high includes it.
By their numbers in this assay, from the lowest: compounds 1, 4 and 2 (each within the scatter of the next); then compound 3.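

In this assay, the tertiary alcohol end of compound 3 is not needed for activity at this position, and replacing it with (1H-1,2,4-triazol-1-yl)methyl reverses the earlier rise: a 3.0-fold lower number from compound 3 to compound 4 (0.48 log units; beyond the scatter). The triazole end also cannot be separated from the two other chain ends, with a 1.2-fold lower number from compound 2 to compound 4 (0.10 log units; within the scatter) and a 1.2-fold higher number from compound 1 to compound 4 (0.09 log units; within the scatter), so this position accepts a five-membered aromatic ring with 3 hetero atoms as well as the phenyl of compound 1 and the hydroxy of compound 2, and among these four compounds only compound 3 stands apart. Nothing at hand gives a reason for these numbers or separates the effect of the ring from that of the lost hydroxy group.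

On these data alone, it remains open whether a primary amine or a carboxylic acid at the same chain end would group with compounds 1, 2 and 4 or stand apart with compound 3. As far as these compounds go, it is also open whether a 1H-imidazol-1-yl end, or a longer chain carrying the triazole, would stay within the scatter of compound 4.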